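The source may hold more compounds than are shown below. What is called first, only, known or untested is meant among the compounds shown, and "the series" means these compounds.

Compound 1 `Cn1ccc2c(Oc3ccc(NC(=O)c4nn(-c5ccc(Cl)cc5)ccc4=O)cc3F)ccnc21` opens this small set. In a functional assay on HepG2 cells (Homo sapiens) for cytotoxicity, read by MTT assay, with a stated time of 72 h (on this read-out higher numbers stand for weaker inhibition and lower numbers for stronger inhibition), compound 1 gives only a limit, > 60000 nM. Compound 2 `Cn1ccc2c(Oc3ccc(NC(=O)c4nn(-c5ccc(Br)cc5F)ccc4=O)cc3F)ccnc21` carries a 4-bromo-2-fluorophenyl on the aromatic nitrogen in place of the 4-chlorophenyl of compound 1, and the resulting step is an at least 2.5-fold lower number from compound 1 to compound 2 (0.39 log units; beyond the scatter). In this assay, among the compounds with values here, compound 2 gives 24000 nM, the only resolved number in the set. The other value, that of compound 1, is a limit (the limit of > 60000 nM in this assay, at which 1 of the 2 values shown sits). Compound 3 `Cn1ccc2c(Oc3ccc(NC(=O)c4nn(-c5ccc(Cl)c(F)c5)ccc4=O)cc3F)ccnc21` has not yet been measured in this assay. It differs from compound 2 by 4-chloro-3-fluorophenyl in place of 4-bromo-2-fluorophenyl on an aromatic nitrogen. Within the data shown here, only one measured step bears on this change, and it bears loosely, since the chlorine returns while a fluorine stays. The expected shift is a 1.5-fold higher number from compound 2 to compound 3 (0.16 log units; within the scatter), toward a somewhat higher number, though not clearly beyond the scatter. Compound 3 is therefore estimated at 35000 nM, with a range from 15000 nM to 80000 nM.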

Compound 3, half-maximal inhibitory concentration: 22100 nM
Compound 3: the middle estimate sits 1.6-fold (0.20 log units) above what was measured, and the stated range covers the measured number.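

The exchange gives a 1.1-fold lower number from compound 2 to compound 3 (0.04 log units; within the scatter), so in this assay the 4-bromo-2-fluorophenyl and the 4-chloro-3-fluorophenyl on the aromatic nitrogen cannot be told apart. Fluoro in place of hydrogen on an aromatic carbon, as the only change, gives an at least 2.7-fold lower number from compound 1 to compound 3 (0.43 log units; beyond the scatter), whereas the earlier step changed the halogen and added fluoro together. The full size of that step stays unresolved, since the value of compound 1 is a limit: the limit of > 60000 nM in this assay, at which 1 of the 3 values shown sits.

The compounds shown carry only halogens on this phenyl ring, so it remains open how a methoxy group, an amine or a carboxylic acid there would read in this assay. They also do not compare bromine with chlorine while the fluoro stays in one place.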